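A few compounds are considered here, and "the series" means these few. Any claim that something is new, unique, unknown or untested is made for them only; others in the source may bear on it.

Working notes on a series of bivalent acylguanidines.

In an in vitro functional assay on Sf9 cells for agonist activity at histamine H2 receptor (Homo sapiens) (on this read-out lower numbers stand for smaller maximal responses and higher numbers for larger maximal responses), compound 1 `Cc1nc(N)sc1CCCN/C(N)=N/C(=O)CCCCCCC(=O)/N=C(\N)NCCCc1sc(N)nc1C` gives 0.62. Compound 2 `N/C(=N\C(=O)CCCCCCC(=O)/N=C(\N)NCCCc1c[nH]cn1)NCCCc1c[nH]cn1` gives 0.77 in this assay, and compound 3 `N/C(=N\C(=O)CCCCCCCCC(=O)/N=C(\N)NCCCc1c[nH]cn1)NCCCc1c[nH]cn1` gives 0.81. Compound 3 stands highest of the three numbers: its gap to compound 2 lies within the scatter, its gap to compound 1 beyond it. For the measured compounds named here, compounds 1 and 2 differ in more than one place, so their two values show only that the pair of 2-amino-4-methyl-1,3-thiazol-5-yl ends sits lower than the pair of 1H-imidazol-4-yl ends on the shorter chain.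

Compound 4 `Cc1nc(N)sc1CCCN/C(N)=N/C(=O)CCCCCCCCC(=O)/N=C(\N)NCCCc1c[nH]cn1` is not yet measured. Against compound 3 the change is 2-amino-4-methyl-1,3-thiazol-5-yl in place of 1H-imidazol-4-yl on a saturated chain carbon, three bonds along the chain from an amine nitrogen, so one end of the two is swapped while the other keeps 1H-imidazol-4-yl. Going by the values given here, no single-change step of this kind has been measured. A modest move downward is expected, because compound 1 gives 0.62 against compound 2 at 0.77 with both ends swapped; with only one end changed the expected step a number 0.080 lower from compound 3 to compound 4 (within the scatter) is small and likely within the scatter. Compound 4 is expected at 0.73 in this assay, in the range 0.62 to 0.84.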

Compound 4, intrinsic activity: the largest response reached, as a fraction of the reference agonist's: 0.76
Compound 4: the middle estimate sits 0.030 below what was measured, and the stated range covers the measured number.
By their numbers in this assay, from the lowest: compound 1; then compounds 4, 2 and 3 (each within the scatter of the next).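

In this assay, for the compounds shown here, the step a number 0.050 lower from compound 3 to compound 4 (within the scatter) is the first reading of 2-amino-4-methyl-1,3-thiazol-5-yl in place of 1H-imidazol-4-yl with only one end changed, and it stays within the scatter at this place, on a saturated chain carbon, three bonds along the chain from an amine nitrogen. The earlier compounds shown here held this end only as a matched pair on the shorter chain, so they could not show what a single swap does, and a mixed compound with one end of each kind now has a reading of its own. No supporting data bear on why the step has this size.

Still open, from the compounds shown here alone, is whether swapping the remaining 1H-imidazol-4-yl end on this chain would give a step beyond the scatter. Also open, going by these compounds, is how a plain 1,3-thiazol-5-yl end without the amine and methyl, or a chain longer than that of compound 3, would read.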